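The source may report more compounds than this note shows. Statements on the series, on what has been measured and on what is new or still open speak of the compounds shown alone.

Measured so far: compound 1 `COc1ccc(/C=N/n2c(CSc3nnc(-c4ccncc4)o3)nc3ccccc3c2=O)cc1` with 20%; compound 2 `O=C1CSC(c2ccc(Cl)cc2)N1n1c(CSc2nnc(-c3ccncc3)o2)nc2ccc(Br)cc2c1=O` with 25.2%; compound 3 `O=c1c2ccccc2nc(CSc2nnc(-c3ccncc3)o2)n1/N=C/c1ccc(O)cc1` with 18.2%.

In a functional assay on the whole organism (strain Charles-Foster albino) for inhibition, with Rattus norvegicus as the target, read by paw edema, at a dose of 50 mg/kg by the oral route (on this read-out lower numbers stand for less inhibition and higher numbers for more inhibition at the one dose given (going by the name of the read-out)), compound 1 stands second highest of the three numbers. Its nearest neighbour is compound 3, with the step of a number 1.8 percentage points lower from compound 1 to compound 3 (within the scatter), and the gap to compound 2 is also within the scatter. Compound 4 `COc1ccc(/C=N/n2c(CSc3nnc(-c4ccncc4)o3)nc3ccc(Br)cc3c2=O)cc1` differs from compound 1 by bromo in place of hydrogen on an aromatic carbon. Among the measured compounds shown here, no measured step isolates this change: compound 2 carries bromine but differs from compound 1 in other places as well, and its value and that of compound 1 lie within the scatter of each other. For the measured compounds named here, the one single-point step, from compound 1 to compound 3, is within the scatter and concerns another place. The step is expected to be a number 2 percentage points higher from compound 1 to compound 4 (within the scatter), nothing beyond the scatter. The estimate for compound 4 is 22%, with a range from 12% to 32%.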

Compound 4, a percentage reported as inhibition, in the whole organism at one dose (the size of the read-out at that dose, not a potency): 24.4%
Beside the measured number, compound 4's estimate is 2.4 percentage points below it, within the range that was stated.
By their numbers in this assay, from the lowest: compounds 3, 1, 4 and 2 (each within the scatter of the next).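

With a number 4.4 percentage points higher from compound 1 to compound 4 (within the scatter) in this assay bromo in place of hydrogen on an aromatic carbon is read on its own, which compound 2 could not offer, since it differs from compound 1 in other places as well. This position, meta to a fused ring and para to a fused ring, thus takes a bromo with a step that stays within the scatter. Nothing measured here speaks to a cause.

Still open, on these data alone, is whether chloro, an amine or a carboxylic acid at this position would give a step beyond the scatter, and whether bromo behaves alike on compound 3.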